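The source may hold more compounds than are shown below. What is called first, only, known or untested is meant among the compounds shown, and "the series" means these compounds.

Among the compounds with values here, compound 3 `CC1(c2ccc(Cl)cc2)CC(S(=O)(=O)c2ccc(F)cc2)=C(c2ccc(/C(N)=N\O)cc2)O1` gives 61400 nM in an ADME assay on HepG2 cells (Homo sapiens) for cytotoxicity, read by MTT assay, with a stated time of 72 h (a higher number here means that more compound is tolerated, a lower number that less compound is tolerated), the highest of the three numbers so far. Compound 2 `CC1(c2ccc(-c3ccccc3C#N)cc2)CC(S(=O)(=O)c2ccc(F)cc2)=C(c2ccc(/C(N)=N\O)cc2)O1` gives 58300 nM in this assay, and the step of a 1.1-fold higher number from compound 2 to compound 3 (0.02 log units; within the scatter) is within the scatter. Compound 1 `CC1(c2ccc(-c3ccc(/C(N)=N\O)cc3)cc2)CC(S(=O)(=O)c2ccc(F)cc2)=C(c2ccc(/C(N)=N\O)cc2)O1` gives 15300 nM in this assay, and the step of a 4.0-fold higher number from compound 1 to compound 3 (0.60 log units; beyond the scatter) is beyond the scatter.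

Compound 4 `CC1(c2ccc(-c3cccc(/C(N)=N\O)c3)cc2)CC(S(=O)(=O)c2ccc(F)cc2)=C(c2ccc(/C(N)=N\O)cc2)O1` differs from compound 3 in one place: a group of 10 heavy atoms (7 carbon, 2 nitrogen, 1 oxygen; one six-membered aromatic ring of carbon only) in place of one chlorine atom, on an aromatic carbon, sitting on an aromatic carbon of a six-membered aromatic ring of carbon only, para to a large group. The change counted here is the reverse of the one seen in a 4.0-fold higher number from compound 1 to compound 3 (0.60 log units; beyond the scatter), where a group of the same size left and a chlorine entered, with a modest rise in the number. The step of a 3.8-fold higher number from compound 1 to compound 2 (0.58 log units; beyond the scatter) points the same way for the removal of such a group. A step of similar size in the opposite direction is therefore expected, a 3.6-fold lower number from compound 3 to compound 4 (0.56 log units; beyond the scatter). Compound 4 is estimated at 17000 nM, with a range from 7000 nM to 45000 nM.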

Compound 4, half-maximal cytotoxic concentration: 19000 nM
Beside the measured number, compound 4's estimate is 1.1-fold (0.05 log units) below it, and the stated range covers the measured number.
By their numbers in this assay, from the lowest: compounds 1 and 4 (each within the scatter of the next); then compounds 2 and 3 (each within the scatter of the next).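

In this assay, the group of 10 heavy atoms in place of chloro gives a 3.2-fold lower number from compound 3 to compound 4 (0.51 log units; beyond the scatter), so a second arrangement of this group at the same aromatic carbon comes with a lower number than chloro. Against the 2-cyanophenyl group the picture is the same, with a 3.1-fold lower number from compound 2 to compound 4 (0.49 log units; beyond the scatter), which shows that among these compounds the lower number follows this particular group and not just any added aromatic ring. Rearranging the group within its ring changes little, with a 1.2-fold higher number from compound 1 to compound 4 (0.09 log units; within the scatter), so the two arrangements cannot be told apart in this assay.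

Still open, from the compounds shown here alone, is whether a carboxylic acid or a simple amine on the added ring would sit with compound 4 or with compound 2. Nothing available here bears on why the group lowers the number.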